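The compounds below may be only part of what the source reports. "The series", "measured", "known", "first", "only" and "open" are said of these compounds alone.

Among the measured compounds shown here, in a functional assay on HCT-116 cells (Homo sapiens) for antiproliferative activity, read by MTT assay, with a stated time of 48 h (on this read-out lower numbers stand for stronger inhibition and higher numbers for weaker inhibition), compound 3 (`COc1cc(N(Cc2ccccc2)C(=O)CSc2nc3ccccc3s2)cc(OC)c1OC`) gives 54500 nM as the higher of the two exact numbers so far. In this assay compound 2 (`COc1ccc(CN(C(=O)CSc2nc3ccccc3s2)c2cc(OC)c(OC)c(OC)c2)cc1[N+](=O)[O-]`) gives 1280 nM as the other. Compound 1 (`COc1cc(N(Cc2ccc(C)cc2)C(=O)CSc2nc3ccccc3s2)cc(OC)c1OC`) shows > 80000 nM as a limit of the assay, not a number.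

Compound 4 (`COc1ccc(CN(C(=O)CSc2nc3ccccc3s2)c2cc(OC)c(OC)c(OC)c2)cc1OC`) carries 3,4-dimethoxyphenyl in place of phenyl on a saturated chain carbon bound to an amide-type nitrogen. The nearest guide is the swap of 4-methoxy-3-nitrophenyl for phenyl (a 43-fold higher number from compound 2 to compound 3 (1.63 log units; beyond the scatter)), a large step. Removing the methyl (an at least 1.4-fold lower number from compound 1 to compound 3 (0.16 log units; that floor lies within the scatter)) shows no change beyond the scatter at its floor. Compound 4 has no nitro group, so a clear drop is expected, though a smaller one than that large step, and the expected change is (a 6.1-fold lower number from compound 3 to compound 4 (0.78 log units; beyond the scatter)). For compound 4 the estimated value is 9000 nM (range 1800 nM to 45000 nM).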

Compound 4, half-maximal inhibitory concentration: 33900 nM
For compound 4 the middle estimate is 3.8-fold (0.58 log units) below the measured one; low and high end bracket the measured number.
By their numbers in this assay, from the lowest: compound 2; then compounds 4 and 3 (each within the scatter of the next). At a limit, above all of these: compound 1.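

In this assay, going from benzyl to 3,4-dimethoxybenzyl adds two methoxy groups yet brings no change beyond the scatter: a 1.6-fold lower number from compound 3 to compound 4 (0.21 log units; within the scatter). Methoxy in place of nitro, by contrast, gives a 26-fold higher number from compound 2 to compound 4 (1.42 log units; beyond the scatter), so the low number of compound 2 goes with its nitro group, not with any added group on this ring. The step of an at least 2.3-fold lower number from compound 1 to compound 4 (0.37 log units; beyond the scatter) is only a floor, since compound 1 stands at a limit of the assay: the limit of > 80000 nM in this assay, at which 1 of the 4 values shown sits.

Going by these compounds, whether an amine or a nitrile in place of nitro would keep that low number remains open. So does the effect of nitro on a ring that carries no methoxy.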